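The source may hold more compounds than are shown below. What is called first, only, known or untested is meant among the compounds shown, and "the series" means these compounds.

Compound 1 `O=C(Nc1cccc(-n2cc(-c3ccncc3)c(-c3ccc(Cl)c(O)c3)n2)c1)Nc1cccc(C(F)(F)F)c1` is the starting point. In a functional assay on SW-620 cells (Homo sapiens) for inhibition, read by sulforhodamine B assay, with a stated time of 48 h (a higher number here means a weaker inhibitor of growth, a lower number a stronger inhibitor of growth), compound 1 gives only a limit of the assay, > 32500 nM. Compound 1 therefore sits at the limit of > 32500 nM in this assay, at which 1 of the 2 values shown sits, with no firm number of its own. Compound 2 `COc1cc(-c2nn(-c3cccc(NC(=O)Nc4cccc(C(F)(F)F)c4)c3)cc2-c2ccncc2)ccc1Cl` gives 14300 nM; the step of an at least 2.2-fold lower number from compound 1 to compound 2 (0.35 log units; beyond the scatter) concerns a methyl placed on an oxygen. Among the measured compounds shown here, compound 3 `O=C(Nc1cccc(-n2cc(-c3ccncc3)c(-c3ccc(Cl)c(O)c3)n2)c1)Nc1ccc(Cl)c(C(F)(F)F)c1` differs from compound 1 by chloro in place of hydrogen on an aromatic carbon, a change on a different ring, so the single measured step does not bear on it. Compound 3 is expected near 30000 nM, within 12000 nM to 80000 nM. That expectation corresponds to an at least 1.0-fold lower number from compound 1 to compound 3 (0.03 log units; that floor lies within the scatter), no change beyond the scatter.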

Compound 3, concentration for total growth inhibition: 4160 nM
The estimate for compound 3 lay 7.2-fold (0.86 log units) above the measured number; the measured number lies below the stated range.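

Putting chloro on the 3-(trifluoromethyl)phenyl ring, ortho to the trifluoromethyl group, gives an at least 7.8-fold lower number from compound 1 to compound 3 (0.89 log units; beyond the scatter) in this assay. Among the compounds shown here, the earlier step concerned the oxygen on the other ring, so this is the first sign that the ring carrying trifluoromethyl also responds to a small change. The size of this step remains a floor because compound 1 has no firm number: the limit of > 32500 nM in this assay, at which 1 of the 3 values shown sits.

From the compounds shown here alone, whether chloro is special at this position remains open, since a methyl group, an amine or a fluorine there could do the same or differ. Also open, going by these compounds, is whether this chloro and the methyl on the oxygen would add up within one compound.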